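The source may report more compounds than this note shows. Statements on the series, on what has been measured and on what is new or still open speak of the compounds shown alone.

Measured compounds in an ADME assay on microsomes from liver (Rattus norvegicus) for metabolic stability, using NADPH, with a stated time of 10 min; a lower number here means that less of the compound is left, a higher number that more of the compound is left: compound 1 `NCCCCN(C[C@H]1Cc2ncccc2CN1)[C@H]1CCCc2cccnc21` gives 64%; compound 2 `NCCCCN(C[C@@H]1Cc2nccnc2CN1)[C@H]1CCCc2cccnc21` gives 67%; compound 3 `NC(=O)NC/C=C\CN(C[C@H]1Cc2ncccc2CN1)[C@H]1CCCc2cccnc21` gives 1%.

Compound 1 stands second highest of the three. Compound 2 lies within the scatter of compound 1, whereas compound 3 lies far lower, the step of a number 63 percentage points lower from compound 1 to compound 3 (beyond the scatter) being large and beyond the scatter. Compound 4 `CCN(CC)CCCCN(C[C@H]1Cc2ncccc2CN1)[C@H]1CCCc2cccnc21` differs from compound 1 by diethylamino in place of amino on a saturated chain carbon, four bonds along the chain from an amine nitrogen. Within the data shown here, the only measured step, a number 63 percentage points lower from compound 1 to compound 3 (beyond the scatter), alters the same chain but exchanges a different group at a different place, so it bears on the new step only loosely; no measured pair sets amino against diethylamino. Compound 4 is therefore expected to sit somewhat lower than compound 1, with a step of a number 14 percentage points lower from compound 1 to compound 4 (beyond the scatter) that may still fall within the scatter. The estimate for compound 4 is 50%, between 25% and 75%.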

Compound 4, percent of the compound remaining: 6%
Estimate against measurement, compound 4: 44 percentage points above, and the stated range ends above it.
By their numbers in this assay, from the lowest: compounds 3 and 4 (each within the scatter of the next); then compounds 1 and 2 (each within the scatter of the next).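

In this assay, the change at the end of the chain alone, diethylamino in place of amino, gives a large step with the rest of compound 1 unchanged: a number 58 percentage points lower from compound 1 to compound 4 (beyond the scatter). Two quite different chain groups now give values within the scatter of each other, a number 5 percentage points higher from compound 3 to compound 4 (within the scatter). Nothing available here explains these results.

The compounds shown leave open whether methylamino or dimethylamino at this place stays with amino or with diethylamino. They also leave open whether diethylamino has the same effect on the core of compound 2.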